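Ring-substituent swap in the bis-benzylidene series: compound 3 to compound 4

The compounds below may be only part of what the source reports. "The series", "measured", "known", "first", "only" and "open" are said of these compounds alone.

Values in an ADME assay on NHDF cells (Homo sapiens) for cytotoxicity, read by MTT assay, with a stated time of 72 h; a higher number here means a weaker inhibitor, a lower number a stronger inhibitor
Compound 1 `COc1cccc(/C=C2\CCC/C(=C\c3ccccc3Cl)C2=O)c1OC` gives 44200 nM
Compound 2 `COc1cccc(/C=C2\CCC/C(=C\c3ccc(Br)cc3)C2=O)c1OC` gives 21400 nM
Compound 3 `COc1ccccc1/C=C1\CCC/C(=C\c2cccc(OC)c2OC)C1=O` gives 31300 nM

In this assay compound 3 at 31300 nM sits within the scatter of the other two, with a 1.4-fold lower number from compound 1 to compound 3 (0.15 log units; within the scatter) and a 1.5-fold higher number from compound 2 to compound 3 (0.17 log units; within the scatter). Compound 4 `COc1ccc(/C=C2\CCC/C(=C\c3cccc(OC)c3OC)C2=O)cc1` carries 4-methoxyphenyl in place of 2-methoxyphenyl on a double-bonded chain carbon bound to a double-bonded ring carbon. Going by the values given here, no measured pair isolates this swap. The closest guide is a 2.1-fold lower number from compound 1 to compound 2 (0.32 log units; beyond the scatter), where 4-bromophenyl replaces 2-chlorophenyl at that same place, a modest step that also changes the halogen. The step of a 1.5-fold higher number from compound 2 to compound 3 (0.17 log units; within the scatter) stays within the scatter. A small move to a lower number is therefore expected, probably not beyond the scatter, as a 1.3-fold lower number from compound 3 to compound 4 (0.12 log units; within the scatter). For compound 4 the estimated value is 24000 nM, with an expected range of 11000 nM to 48000 nM.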

Compound 4, half-maximal inhibitory concentration: 43500 nM
For compound 4 the middle estimate is 1.8-fold (0.26 log units) below the measured one; low and high end bracket the measured number.
By their numbers in this assay, from the lowest: compounds 2, 3, 4 and 1 (each within the scatter of the next, the first and the last beyond it).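

In this assay the swap to 4-methoxyphenyl from 2-methoxyphenyl gives a 1.4-fold higher number from compound 3 to compound 4 (0.14 log units; within the scatter) and so does not separate the two methoxy isomers. Methoxy in place of bromo gives a 2.0-fold higher number from compound 2 to compound 4 (0.31 log units; beyond the scatter) as a modest step, whereas 4-methoxyphenyl in place of 2-chlorophenyl gives a 1.0-fold lower number from compound 1 to compound 4 (0.01 log units; within the scatter) with no separation. At this place 4-bromophenyl alone stands apart, from compound 1 and compound 4 but not from compound 3.

As far as these compounds go, whether an amine or a carboxylic acid on this aromatic ring would shift the number beyond the scatter remains open. Nothing available explains these steps.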